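Third aryl variant of a scaffold showing no cytotoxicity

A few compounds are considered here, and "the series" means these few. Any claim that something is new, unique, unknown or untested is made for them only; others in the source may bear on it.

Compound 1 `O=C(c1ccc2c(c1)OCCO2)C1CCN(Cc2coc(-c3ccc(Br)cc3)n2)CC1` gives > 150 ug/mL.
Compound 2 `O=C(c1ccc2c(c1)OCCO2)C1CCN(Cc2coc(-c3ccc(F)c(F)c3)n2)CC1` gives > 150 ug/mL.

In an ADME assay on HEK293 cells (Homo sapiens) for cytotoxicity, read by MTT assay, with a stated time of 36 h (on this read-out lower numbers stand for stronger inhibition and higher numbers for weaker inhibition), compound 1 reaches only > 150 ug/mL, which is a limit of the assay rather than a measured number. Compound 2 likewise reaches only > 150 ug/mL, again a limit. The change between them is a step that the two limits leave unreadable from compound 1 to compound 2, so its size cannot be read. Where compound 2 stands is therefore known only as a limit, and the limit of > 150 ug/mL in this assay, at which 2 of the 2 values shown sit, gathers every value seen so far.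

Compound 3 `CC(C)(C)c1ccc(-c2nc(CN3CCC(C(=O)c4ccc5c(c4)OCCO5)CC3)co2)cc1` carries the change (4-(tert-butyl)phenyl in place of 3,4-difluorophenyl on an aromatic carbon). For the measured compounds named here, the one measured step bearing on it is unreadable, so no direction beyond the scatter can be expected; compound 3 is estimated to stay at the same limit, 150 ug/mL, with a range from 60 ug/mL to 300 ug/mL. The step this estimate means, a number no higher from compound 2 to compound 3 (the limit leaves the size open), is expected to be nil.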

Compound 3, half-maximal inhibitory concentration: > 150 ug/mL
Compound 3 ended at the assay's limit; the forecaster's own chance of this, stated with the estimate: 75%; the middle value sits exactly at the limit.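

In this assay compound 3 gives > 150 ug/mL, which is a limit and not a number. The steps among compound 1, compound 2 and compound 3 therefore cannot be read. The compounds shown leave open at what concentration, if any, each would reach half-maximal inhibition.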